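Chloro for fluoro on two related aryl cores

This account rests on a few compounds, and the source may have more. Where it says the series, first, only, none or still open, it means among the compounds named here.

Compound 1 `CS(=O)(=O)c1cc(F)ccc1NCC1=NCCN1` carries a methylsulfonyl group, while compound 2 `CSc1ccc(F)cc1NCC1=NCCN1` and compound 3 `CSc1ccc(Cl)cc1NCC1=NCCN1` share a core with a methylsulfanyl group; the difference between the two cores is not broken down here. In an assay on CHO cells for binding affinity to Alpha-2B adrenergic receptor (Homo sapiens), read by radioligand binding (on this read-out lower numbers stand for stronger inhibition and higher numbers for weaker inhibition), compound 2 gives 331 nM and compound 3 gives 676 nM. The change between them, (chloro in place of fluoro on an aromatic carbon), gives a 2.0-fold higher number from compound 2 to compound 3 (0.31 log units; beyond the scatter). For compound 1 only a limit is known, < 6310 nM, as noted in the limit of < 6310 nM in this assay, at which 1 of the 3 values shown sits. Compound 4 `CS(=O)(=O)c1cc(Cl)ccc1NCC1=NCCN1` is not yet measured. The change chloro in place of fluoro on an aromatic carbon is the same kind of change, but its surroundings differ: it sits meta to a methylsulfonyl group and para to a group of 7 heavy atoms. Compound 4 is therefore expected to show a step that the limit leaves unreadable from compound 1 to compound 4, resting on the step from compound 2 to compound 3 a 2.0-fold higher number from compound 2 to compound 3 (0.31 log units; beyond the scatter). Compound 4 is estimated at 5000 nM, between 1500 nM and 20000 nM.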

Compound 4, inhibition constant: < 6310 nM
Compound 4 was reported as a limit (the forecaster's own chance of this, stated with the estimate: 50%); the middle value lies beyond the limit too.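

No step from compound 1 to compound 4 can be read, because in this assay both are reported only as limits: the limit of < 6310 nM in this assay, at which 2 of the 4 values shown sit.

As far as these compounds go, whether chloro in place of fluoro on the core of compound 1 acts as it does on the core of compound 2 stays open.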